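Swapping the pendant aryl group for a pyrazolyl-phenyl

A few compounds are considered here, and "the series" means these few. Any claim that something is new, unique, unknown or untested is made for them only; others in the source may bear on it.

Compound 1, `COc1ccccc1-c1cccc2nc(Nc3cc(OC)c(OC)c(OC)c3)oc12`, gives 20 nM in an assay on isolated protein for inhibition of ribosomal protein S6 kinase alpha-2 (Homo sapiens), with a stated time of 150 min; a lower number here means a stronger inhibitor, a higher number a weaker inhibitor.
Compound 2, `COc1cc(Nc2nc3cccc(-c4ccccc4OC(F)(F)F)c3o2)cc(OC)c1OC`, gives 4000 nM in this assay.
Compound 3, `COc1ccc(F)cc1-c1cccc2nc(Nc3cc(OC)c(OC)c(OC)c3)oc12`, gives 40 nM in this assay.

Compound 3 holds the second highest of the three numbers. Compound 1 lies nearest to it, with a 2.0-fold higher number from compound 1 to compound 3 (0.30 log units; within the scatter). Compound 2 lies furthest away, with a 100-fold lower number from compound 2 to compound 3 (2.00 log units; beyond the scatter).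

Compound 4, `COc1cc(Nc2nc3cccc(-c4ccccc4-c4cn[nH]c4)c3o2)cc(OC)c1OC`, has not yet been measured. Its change from compound 3 is a group of 11 heavy atoms (9 carbon, 2 nitrogen; one five-membered aromatic ring with 2 hetero atoms, one six-membered aromatic ring of carbon only) in place of a group of 9 heavy atoms (7 carbon, 1 oxygen, 1 fluorine; one six-membered aromatic ring of carbon only), on an aromatic carbon.

Two of the measured steps bear on this. Changing the group on that same aromatic carbon brought a 200-fold higher number from compound 1 to compound 2 (2.30 log units; beyond the scatter), a large move, and reversing to a closely related group brought a 100-fold lower number from compound 2 to compound 3 (2.00 log units; beyond the scatter). Only the small change of a fluoro for a hydrogen, a 2.0-fold higher number from compound 1 to compound 3 (0.30 log units; within the scatter), stayed within the scatter. The new group in compound 4 is a larger departure than any of these, so a move beyond the scatter toward a higher number is expected in this assay, though with wide uncertainty because nothing measured carries this new ring.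

Compound 4 is therefore estimated at 300 nM, within the range 30 nM to 3000 nM, which corresponds to an expected 7.5-fold higher number from compound 3 to compound 4 (0.88 log units; beyond the scatter).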

Compound 4, half-maximal inhibitory concentration: 9300 nM
The estimate for compound 4 lay 31-fold (1.49 log units) below the measured number, outside the stated range (above it).
By their numbers in this assay, from the lowest: compounds 1 and 3 (each within the scatter of the next); then compound 2; then compound 4.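

In this assay the whole pendant aryl group changes in a 230-fold higher number from compound 3 to compound 4 (2.37 log units; beyond the scatter) and the change of methoxy alone to 1H-pyrazol-4-yl gives a 470-fold higher number from compound 1 to compound 4 (2.67 log units; beyond the scatter) as the largest step among these compounds. Until now, only trifluoromethoxy had shown that replacing methoxy on this phenyl ring could cost so much, yet the new ring also ends at the weak end of the series, with a 2.3-fold higher number from compound 2 to compound 4 (0.37 log units; beyond the scatter) still separating the two replacements. Across these four compounds, the two that keep methoxy, compound 1 and compound 3, inhibit more strongly than the two that lack it, compound 2 and compound 4, and none goes against this pattern.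

Nothing measured here explains why either replacement weakens inhibition so strongly. As far as these compounds go, it remains open whether an ethoxy or a hydroxyl group in place of methoxy would hold the low number, and whether adding the fluoro of compound 3 to the ring that carries the 1H-pyrazol-4-yl group would change the result.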